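The compounds below may be only part of what the source reports. "The series", "measured", "known", "first", "only" and "open" are said of these compounds alone.

Measured so far:
- compound 2, `O=C(C1CCS(=O)(=O)CC1)N1CC[C@](c2ccc(C(F)(C(F)(F)F)C(F)(F)F)cc2)(S(=O)(=O)c2ccc(F)cc2)C1`, 93%
- compound 3, `O=C(N1CC[C@](c2ccc(C(F)(C(F)(F)F)C(F)(F)F)cc2)(S(=O)(=O)c2ccc(F)cc2)C1)C1(F)CCS(=O)(=O)CC1`, 100%
- compound 1, `O=C(O)[C@H]1CC[C@](F)(C(=O)N2CC[C@](c3ccc(C(F)(C(F)(F)F)C(F)(F)F)cc3)(S(=O)(=O)c3ccc(F)cc3)C2)CC1`, "not determined" (no result reported)

Compound 1 carries a 4-carboxy-1-fluorocyclohexyl group on the carbonyl carbon next to the ring amide nitrogen; in an ADME assay on microsomes from liver (Homo sapiens) for metabolic stability, with a stated time of 10 min (a higher number here means that more of the compound is left, a lower number that less of the compound is left), no number was reported for compound 1, so it stands nowhere on the measured scale. Compound 4 is `O=C(N1CC[C@](c2ccc(C(F)(C(F)(F)F)C(F)(F)F)cc2)(S(=O)(=O)c2ccc(F)cc2)C1)C1(CO)CCS(=O)(=O)CC1`. Compared with compound 1 it differs in one place: 4-(hydroxymethyl)-1,1-dioxothian-4-yl in place of 4-carboxy-1-fluorocyclohexyl on a carbonyl carbon. Among the compounds with values here, the only measured step runs between compound 2 and compound 3, both of which carry the 1,1-dioxothian-4-yl ring found in compound 4; there a number 7 percentage points higher from compound 2 to compound 3 (within the scatter). Both of those compounds remain almost fully intact in this assay, and compound 4 shares the same core and the same sulfur-containing ring, differing only in its hydroxymethyl group. Compound 4 is therefore expected to give a high reading in this assay as well, estimated at 88% with a range from 68% to 100%.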

Compound 4, percent of the compound remaining: 75%
Compound 4: middle estimate off by 13 percentage points, on the high side; low and high end bracket the measured number.
By their numbers in this assay, from the lowest: compound 4; then compounds 2 and 3 (each within the scatter of the next).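

In this assay, the saturated ring carbon on the carbonyl turns out not to be indifferent to what it carries: hydroxymethyl in place of fluoro gives a number 25 percentage points lower from compound 3 to compound 4 (beyond the scatter) and hydroxymethyl in place of hydrogen gives a number 18 percentage points lower from compound 2 to compound 4 (beyond the scatter) for the same ring. The earlier change at this carbon, fluoro in place of hydrogen, gave only a number 7 percentage points higher from compound 2 to compound 3 (within the scatter) and so could not show that a substituent here can move the reading at all. Nothing measured here bears on why the reading falls.

The compounds shown leave open whether the lower number goes with the hydroxyl or with the added carbon, since a plain methyl group on this carbon is not among them. They also cannot say how an amine, a carboxylic acid or a longer chain ending in a hydroxyl would fare at this carbon.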